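Notes on the aryl swap at the ring nitrogen

The compounds below may be only part of what the source reports. "The series", "measured", "known", "first", "only" and "open" are said of these compounds alone.

Compound 3 `C[C@H](Nc1ncnc2[nH]cnc12)c1nn(-c2cccnc2)c2cc(F)ccc12` is the reference point for this step. Within the data shown here, in a functional assay on Bel-7402 cells (Homo sapiens) for inhibition, read by sulforhodamine B assay, with a stated time of 72 h, tested at 10 uM (on this read-out lower numbers stand for less inhibition and higher numbers for more inhibition at the one concentration tested (going by the name of the read-out)), compound 3 gives 8%, which is the second highest of the three numbers known; its nearest neighbour is compound 1, its furthest compound 2. Compound 1 `C[C@H](Nc1ncnc2[nH]cnc12)c1nn(-c2cccnc2)c2cc(Cl)ccc12` carries chloro where compound 3 carries fluoro, and in this assay compound 1 gives 17%; the step of a number 9 percentage points lower from compound 1 to compound 3 (within the scatter). Compound 2 `C[C@H](Nc1nc(N)nc2[nH]cnc12)c1nn(-c2cccnc2)c2cc(F)ccc12` carries amino on the core where compound 3 carries hydrogen, and in this assay compound 2 gives -5%; the step of a number 13 percentage points higher from compound 2 to compound 3 (beyond the scatter).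

Compound 4 `C[C@H](Nc1ncnc2[nH]cnc12)c1nn(-c2cc(F)cc(F)c2)c2cc(F)ccc12` is not yet measured. Its change from compound 3 is 3,5-difluorophenyl in place of pyridin-3-yl on an aromatic nitrogen. Neither measured step touches this group: one changes a halogen on an aromatic carbon, the other a substituent on the core, and both keep the pyridin-3-yl in place. Among the measured compounds shown here, no measured step therefore bears on the present change, and the data give no direction for it.

The step of a number 4 percentage points higher from compound 3 to compound 4 (within the scatter) is expected to stay within the scatter, as nothing known points elsewhere. For compound 4 the estimate in this assay is 12%, with a range from -8% to 35%.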

Compound 4, a percentage reported as inhibition, at one concentration (the size of the read-out at that concentration, not a potency): -8%
Compound 4: middle estimate off by 20 percentage points, on the high side, and the stated range covers the measured number.
By their numbers in this assay, from the lowest: compounds 4 and 2 (each within the scatter of the next); then compounds 3 and 1 (each within the scatter of the next).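

In this assay, among these compounds, the step of a number 16 percentage points lower from compound 3 to compound 4 (beyond the scatter) is the first measured change at the group on the aromatic nitrogen, and it shows that the read-out responds to this position, with a shift larger than the usual scatter. Compound 4 gives -8%, a negative number, so replacing pyridin-3-yl with 3,5-difluorophenyl brings no gain in inhibition over compound 3 at the one concentration tested. Nothing measured here bears on why the number moves in this direction.

The change removes the ring nitrogen and its hydrogen-bond acceptor and adds two fluorines in a single step, so the compounds shown cannot say which part of the swap goes with the lower number, and a plain phenyl or a methoxy-substituted pyridin-3-yl on the same nitrogen would help to separate these parts. From the compounds shown here alone, it also remains open whether the same swap gives a step of similar size and direction with chloro in place of fluoro on the core, or with the amino group of compound 2 present.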